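The compounds below may be only part of what the source reports. "The series", "measured", "known", "first", "only" and "open" are said of these compounds alone.

Measured compounds:
- compound 1 `Cn1c(Cc2nn(C)c(=O)c3ccccc23)nnc1SCCCCCCCCCCCCCCCC(=O)Nc1ccc(Cl)cc1Cl` gives 7300 nM in an assay on isolated protein (Mus musculus) for inhibition of IL15-IL15 receptor (Homo sapiens), read by resazurin assay, with stated times of 30 min and 2.5 days; on this read-out lower numbers stand for stronger inhibition and higher numbers for weaker inhibition
- compound 2 `CC(C)COc1ccc(NC(=O)CCCCCCCSc2nnc(Cc3nn(C)c(=O)c4ccccc34)n2C)cc1` gives 4800 nM in this assay
- compound 3 `Cn1c(Cc2nn(C)c(=O)c3ccccc23)nnc1SCCCC(=O)Nc1ccc(Cl)cc1Cl` gives 9800 nM in this assay

Among these three numbers, compound 2 holds the lowest one. Compound 1 comes nearest, and its number lies within the usual scatter of compound 2, so the two cannot be told apart; compound 3 sits furthest away, beyond the scatter. Among the measured compounds shown here, all three share the same core, and they differ in the length of the sulfur-linked chain and in what sits on the aniline ring, so no single-point step between them can be drawn.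

Compound 4 `Cn1c(Cc2nn(C)c(=O)c3ccccc23)nnc1SCCCCCCCC(=O)Nc1ccc(I)cc1` keeps the chain length of compound 2 and changes only the aniline substituent: iodo in place of isobutoxy on an aromatic carbon. For the measured compounds named here, no measured pair shows this change on its own, so its effect has to be guessed. The shared features of all three compounds give numbers of the same rough size, and the expectation is a step from compound 2 to compound 4 of a 1.4-fold higher number from compound 2 to compound 4 (0.13 log units; within the scatter), that is, no change beyond the scatter. Compound 4 is therefore estimated at 6500 nM, with a range from 2500 nM to 17000 nM.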

Compound 4, half-maximal inhibitory concentration: 1300 nM
Beside the measured number, compound 4's estimate is 5.0-fold (0.70 log units) above it; measured number below the stated range.
By their numbers in this assay, from the lowest: compound 4; then compounds 2, 1 and 3 (each within the scatter of the next, the first and the last beyond it).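

In this assay, replacing isobutoxy with iodo on an aromatic carbon gives a 3.7-fold lower number from compound 2 to compound 4 (0.57 log units; beyond the scatter), with the chain length unchanged. Among the compounds shown here, this is the first step here that can be tied to a single place in the structure. It shows that the isobutoxy group, with its 5 heavy atoms and 1 hydrogen-bond acceptor, is not needed at this position, since a single iodine atom with no acceptor gives stronger inhibition. No measurement shown here bears on the reason for this step.

The swap removes the oxygen and the carbons and adds iodine all at once, so the compounds shown leave open which of these changes matters. Going by these compounds, a bromo, a methoxy or an amine at the same position could help separate them, and whether the step holds with a longer chain also remains open.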